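The source may report more compounds than this note shows. Statements on the series, on what has been measured and on what is new or still open speak of the compounds shown alone.

Compound 1, `C#CCN(CC)Cc1cn(-c2cc(NC(=S)NCC)ncn2)cn1`: 6.71%
Compound 2, `C#CCN(CCC)Cc1cn(-c2cc(NC(=S)NCC)ncn2)cn1`: 1.76%
Compound 3, `C#CCN(CC#N)Cc1cn(-c2cc(NC(=S)NCC)ncn2)cn1`: 2.01%

In an assay on isolated protein for inhibition of Amine oxidase [flavin-containing] A (Homo sapiens), read by fluorescence and Amplex Red, with a stated time of 15 min, tested at 50 uM (a lower number here means less inhibition, a higher number more inhibition at the concentration tested (going by the name of the read-out)), compound 1 gives the highest of the three numbers, yet each of its steps to the others stays within the scatter: a number 5 percentage points lower from compound 1 to compound 2 (within the scatter) and a number 4.7 percentage points lower from compound 1 to compound 3 (within the scatter). The remaining step likewise stays within the scatter: a number 0.3 percentage points higher from compound 2 to compound 3 (within the scatter). Compound 4, `C#CCN(CC#C)Cc1cn(-c2cc(NC(=S)NCC)ncn2)cn1`, differs from compound 1 by ethynyl in place of methyl on a saturated chain carbon bound to an amine nitrogen. The three measured steps bear on this change, as each alters the group on the same saturated chain carbon, and none of them moved the number beyond the scatter. No step beyond the scatter is therefore expected for compound 4 either. Compound 4 is estimated at 4.5%, with a range from 0% to 12%, which means an expected step of a number 2.2 percentage points lower from compound 1 to compound 4 (within the scatter).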

Compound 4, a percentage reported as inhibition, at one concentration (the size of the read-out at that concentration, not a potency): 15.5%
Estimate against measurement, compound 4: 11 percentage points below; measured number above the stated range.
By their numbers in this assay, from the lowest: compounds 2, 3, 1 and 4 (each within the scatter of the next, the first and the last beyond it).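

For the compounds shown here, at this saturated chain carbon bound to an amine nitrogen, ethynyl is the first group to stand apart in this assay, with a number 13.5 percentage points higher from compound 3 to compound 4 (beyond the scatter) and a number 13.7 percentage points higher from compound 2 to compound 4 (beyond the scatter) both beyond the scatter, though modest. The change from methyl stays within the scatter, a number 8.8 percentage points higher from compound 1 to compound 4 (within the scatter), so compound 4 cannot be ranked above compound 1. Nothing available explains why ethynyl separates from ethyl and cyano. Still open, on these data alone, is whether a phenyl ring, a hydroxyl or a longer chain carrying a terminal alkyne on this carbon would match ethynyl.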